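The source may report more compounds than this note shows. Statements on the series, on what has been measured and on what is new or still open speak of the compounds shown alone.

Working notes on the series. All three measured compounds share one core and differ only in the substituent on the saturated chain carbon bound to a nitrogen on an aromatic ring. Compound 3 `CCN(Cc1ccccc1)c1ccc(C(=O)N2CCc3ccc(OS(N)(=O)=O)cc3C2)cc1` gives 66.9% in an assay on HEK293 cells for inhibition of Steryl-sulfatase (Homo sapiens), tested at 0.1 uM (a higher number here means a stronger effect of the compound at the concentration tested, a lower number a weaker effect), the highest of the three numbers. Compound 1 `CCN(Cc1ccccn1)c1ccc(C(=O)N2CCc3ccc(OS(N)(=O)=O)cc3C2)cc1` gives 42.5% in this assay, and compound 2 `CCN(Cc1cccnc1)c1ccc(C(=O)N2CCc3ccc(OS(N)(=O)=O)cc3C2)cc1` gives 35.7%. The steps of a number 24.4 percentage points higher from compound 1 to compound 3 (beyond the scatter) and a number 31.2 percentage points higher from compound 2 to compound 3 (beyond the scatter) lie beyond the scatter, whereas a number 6.8 percentage points lower from compound 1 to compound 2 (within the scatter) does not.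

Compound 4 `NS(=O)(=O)Oc1ccc2c(c1)CN(C(=O)c1ccc(N(CCCO)Cc3ccccc3)cc1)CC2` differs from compound 3 by hydroxymethyl in place of hydrogen on a saturated chain carbon, two bonds along the chain from a nitrogen on an aromatic ring. Going by the values given here, this change sits on the saturated chain carrying the nitrogen, not on the carbon where the three measured compounds differ, so none of the measured steps bears on it directly; all three steps concern the ring on the saturated chain carbon. With nothing in the measured set to point either way, no step beyond the scatter is expected. Compound 4 is therefore estimated at 60% in this assay, with a range from 40% to 80%, which means an expected step of a number 6.9 percentage points lower from compound 3 to compound 4 (within the scatter).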

Compound 4, a percentage reported as inhibition, at one concentration (the size of the read-out at that concentration, not a potency): 5.7%
Compound 4: middle estimate off by 54.3 percentage points, on the high side, and the stated range ends above it.
By their numbers in this assay, from the lowest: compound 4; then compounds 2 and 1 (each within the scatter of the next); then compound 3.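

The chain on the nitrogen, untouched in the three earlier compounds, is not a silent position. With the phenyl held constant, going from ethyl to 3-hydroxypropyl gives a number 61.2 percentage points lower from compound 3 to compound 4 (beyond the scatter) in this assay, so a change of only 2 heavy atoms at this place can nearly remove the effect at the concentration tested. Nothing available explains this drop.

As far as these compounds go, it remains open whether the drop follows from the hydroxyl or from the longer chain, and a plain propyl chain would separate the two, while a methoxy or an amine at the chain end would show whether other end groups behave like the hydroxyl. Also open, from the compounds shown here alone, is whether the same chain change would act alike with the pyridin-2-yl or pyridin-3-yl ring in place of phenyl.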